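Shortening an amide chain on two related cores

The source may report more compounds than this note shows. Statements on the series, on what has been measured and on what is new or still open speak of the compounds shown alone.

Measured so far in a physicochemical assay for lipophilicity, read by HPLC, measured as chromatographic lipophilicity, at pH 7.4; a higher number here means a more lipophilic compound, a lower number a more polar compound:
compound 1 `CCCCCCCC(=O)NCCCN1C[C@H](C)C[C@@](C)(O)[C@H](O[C@@H]2O[C@H](C)C[C@H](N(C)C)[C@H]2O)[C@@H](C)[C@H](O[C@H]2C[C@@](C)(OC)[C@@H](O)[C@H](C)O2)[C@@H](C)C(=O)O[C@H](CC)[C@@](C)(O)[C@H](O)[C@H]1C` gives 3.74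
compound 2 `CCC(=O)NCCCO[C@@H]1[C@@H](C)N(C)C[C@H](C)C[C@@](C)(O)[C@H](O[C@@H]2O[C@H](C)C[C@H](N(C)C)[C@H]2O)[C@@H](C)[C@H](O[C@H]2C[C@@](C)(OC)[C@@H](O)[C@H](C)O2)[C@@H](C)C(=O)O[C@H](CC)[C@@]1(C)O` gives 2.74
compound 3 `CCCCCCCC(=O)NCCCO[C@@H]1[C@@H](C)N(C)C[C@H](C)C[C@@](C)(O)[C@H](O[C@@H]2O[C@H](C)C[C@H](N(C)C)[C@H]2O)[C@@H](C)[C@H](O[C@H]2C[C@@](C)(OC)[C@@H](O)[C@H](C)O2)[C@@H](C)C(=O)O[C@H](CC)[C@@]1(C)O` gives 5.18

Compound 3 and compound 2 share a core and differ in one place, (hydrogen in place of pentyl on a saturated chain carbon, two bonds along the chain from a carbonyl carbon). That change gives a number 2.44 log units lower from compound 3 to compound 2 (beyond the scatter), so the longer chain of compound 3 is markedly more lipophilic than the short chain of compound 2.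

Compound 4 `CCC(=O)NCCCN1C[C@H](C)C[C@@](C)(O)[C@H](O[C@@H]2O[C@H](C)C[C@H](N(C)C)[C@H]2O)[C@@H](C)[C@H](O[C@H]2C[C@@](C)(OC)[C@@H](O)[C@H](C)O2)[C@@H](C)C(=O)O[C@H](CC)[C@@](C)(O)[C@H](O)[C@H]1C` has not yet been measured. It relates to compound 1 in the same way, (hydrogen in place of pentyl on a saturated chain carbon, two bonds along the chain from a carbonyl carbon), with the place described in the same words. The difference between the core of compound 1 and the core of compound 3 is not broken down here; in this assay compound 1 sits between compound 2 and compound 3.

If the chain shortening behaves as it did on the other core, a step of a number 2.44 log units lower from compound 1 to compound 4 (beyond the scatter) is expected, because the earlier change gave a number 2.44 log units lower from compound 3 to compound 2 (beyond the scatter). Compound 4 is therefore estimated at 1.3, with a likely range from 0.7 to 1.9.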

Compound 4, distribution coefficient: 1.86
Compound 4: the middle estimate sits 0.56 log units below what was measured; the measured number falls inside the stated range.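

In this assay, replacing pentyl with hydrogen gives a number 1.88 log units lower from compound 1 to compound 4 (beyond the scatter) on this core, and the same change gave a number 2.44 log units lower from compound 3 to compound 2 (beyond the scatter) on the other core. These two pairs show that the direction of the change carried from one core to the other and that the step was large on both, but they do not show that its size is fixed or that it would repeat on any further core. Nothing measured here explains the size of either step.

The compounds shown leave open where a butanoyl chain would fall on either core. They also leave open what an amine or a carboxylic acid in place of the chain would give in this assay on these cores.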